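The source may hold more compounds than are shown below. What is called first, only, known or untested is meant among the compounds shown, and "the series" means these compounds.

Measured compounds:
Compound 1 `COc1cc(NC(C)CCCNC(=O)NNC(=O)Nc2cccc(F)c2)c2ncccc2c1`: in a functional assay on HeLa cells (Homo sapiens) for inhibition, read by MTT assay, with a stated time of 72 h (a higher number here means a weaker inhibitor, a lower number a stronger inhibitor), compound 1 reaches only > 250000 nM, which is a limit of the assay and not a number.
Compound 2 `COc1cc(NC(C)CCCNC(=O)Nc2ccc(C(F)(F)F)cc2)c2ncccc2c1`: in this assay compound 2 gives 8300 nM.

Compound 1 therefore stands at the limit of > 250000 nM in this assay, at which 1 of the 2 values shown sits, with no number of its own. Compound 3 `COc1cc(NC(C)CCCNC(=O)NNC(=O)Nc2cccc(C(F)(F)F)c2)c2ncccc2c1` differs from compound 1 by trifluoromethyl in place of fluoro on an aromatic carbon. Going by the values given here, the only measured step, an at least 30-fold lower number from compound 1 to compound 2 (1.47 log units; beyond the scatter), alters a different part of the molecule, so it does not bear on this change. Among the compounds with values here, with no guiding step, the expected step is a number no higher from compound 1 to compound 3 (the limit leaves the size open), keeping the value near the limit. Compound 3 is estimated at 250000 nM, with a range from 50000 nM to 1000000 nM.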

Compound 3, half-maximal inhibitory concentration: 4900 nM
The estimate for compound 3 lay 51-fold (1.71 log units) above the measured number; the measured number lies below the stated range.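

On this aromatic carbon, trifluoromethyl in place of fluoro gives an at least 51-fold lower number from compound 1 to compound 3 (1.70 log units; beyond the scatter), so a single change here, with the rest of the molecule kept, is enough to yield a measurable value in this assay. The earlier step altered a different part of the molecule and could not show this. Compound 1 has only a limit and not a number, so the step has no upper bound: the limit of > 250000 nM in this assay, at which 1 of the 3 values shown sits.

The compounds shown leave open how other groups on this carbon, such as chloro, methoxy or an amine, would compare.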